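Adding a second methoxy to the phenyl of compound 3

The source may hold more compounds than are shown below. What is called first, only, known or untested is meant among the compounds shown, and "the series" means these compounds.

Of the compounds shown here, three built on one shared core have been tested in a functional assay on A549 cells (Homo sapiens) for antiproliferative activity, read by MTT assay, with a stated time of 48 h; a lower number here means a stronger inhibitor, a higher number a weaker inhibitor. Compound 1 `N#CC1=C(N)Oc2c(c3nc4ccccc4nc3c3ccccc23)C12C(=O)N(Cc1cnnn1-c1ccc(N)cc1)c1ccccc12` gives a result that is a limit of the assay rather than a number, > 50000 nM. Compound 2 `N#CC1=C(N)Oc2c(N)cc3nc4ccccc4nc3c2C12C(=O)N(Cc1cnnn1-c1ccccc1Cl)c1ccccc12` gives 29800 nM in this assay. Compound 3 `COc1ccccc1-n1nncc1CN1C(=O)C2(C(C#N)=C(N)Oc3c(N)cc4nc5ccccc5nc4c32)c2ccccc21` gives 37500 nM. Within the data shown here, of the two numbers given, the one for compound 3 is the higher, yet its gap to compound 2 is within the scatter: a 1.3-fold higher number from compound 2 to compound 3 (0.10 log units; within the scatter). Among the measured compounds shown here, that single step, methoxy in place of chloro on an aromatic carbon, is the only measured change in this set, and it moved the number by an amount that repeated measurements could produce on their own.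

Compound 4 `COc1ccc(OC)c(-n2nncc2CN2C(=O)C3(C(C#N)=C(N)Oc4c(N)cc5nc6ccccc6nc5c43)c3ccccc32)c1` differs from compound 3 in one place: methoxy in place of hydrogen on an aromatic carbon. For the measured compounds named here, the one measured step, from chloro to methoxy, bears on this change only loosely, since here a methoxy replaces a hydrogen rather than a chloro. Because that step a 1.3-fold higher number from compound 2 to compound 3 (0.10 log units; within the scatter) stayed within the scatter, no step beyond the scatter is expected in this assay in either direction for compound 4. Compound 4 is therefore estimated at 40000 nM, with a range from 18000 nM to 90000 nM. The expected step is a 1.1-fold higher number from compound 3 to compound 4 (0.03 log units; within the scatter).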

Compound 4, half-maximal inhibitory concentration: 28100 nM
Estimate against measurement, compound 4: 1.4-fold (0.15 log units) above; the measured number falls inside the stated range.
By their numbers in this assay, from the lowest: compounds 4, 2 and 3 (each within the scatter of the next). At a limit, above all of these: compound 1.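

In this assay, among these compounds, the earlier steps showed only one group swapped for another on the phenyl ring, whereas here a group is added where a hydrogen stood. A second methoxy on an aromatic carbon, para to the first methoxy group and meta to a large group, gives a 1.3-fold lower number from compound 3 to compound 4 (0.13 log units; within the scatter), so adding this group at this carbon shifts the number by no more than repeated measurements could produce. The full replacement of 2-chlorophenyl by 2,5-dimethoxyphenyl gives a 1.1-fold lower number from compound 2 to compound 4 (0.03 log units; within the scatter), so the three phenyl groups on the shared core, in compounds 2, 3 and 4, cannot be told apart in this assay, while compound 1, which differs in more than one place, gives only a limit of the assay: the limit of > 50000 nM in this assay, at which 1 of the 4 values shown sits.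

On these data alone, it remains open whether a different group on this same carbon, such as a carboxylic acid, a hydroxyl or a longer chain like butoxy, would move the number beyond the scatter. Also open, as far as these compounds go, is what the methoxy on this carbon would do alone, with a hydrogen in place of the 2-methoxy group.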